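A few compounds are considered here, and "the series" means these few. Any claim that something is new, unique, unknown or untested is made for them only; others in the source may bear on it.

Measured so far:
compound 1, `FC(F)(F)c1nc2c(Br)cccc2c(Cl)c1Br`: > 300000 nM
compound 2, `Fc1ccc(-c2c(C(F)(F)F)nc3c(-c4ccc(F)cc4)cccc3c2-c2ccc(F)cc2)cc1`: > 300000 nM

Both entries in an assay for inhibition of ectonucleoside triphosphate diphosphohydrolase 3 (Homo sapiens), read by malachite green, with a stated time of 10 min (a higher number here means a weaker inhibitor, a lower number a stronger inhibitor), are limits of the assay rather than numbers. For compound 1 the reading > 300000 nM is such a limit. For compound 2 the reading > 300000 nM is likewise a limit. Compound 1 therefore stands at the ceiling of what this assay reports, with no ranking possible between it and compound 2; the only thing on record is the limit of > 300000 nM in this assay, at which 2 of the 2 values shown sit.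

Compound 3, `FC(F)(F)c1nc2c(-c3ccsc3)cccc2c(Cl)c1Br`, has not been run in this assay. It differs from compound 1 by thiophen-3-yl in place of bromo on an aromatic carbon. Going by the values given here, no step between two measured compounds exists, so there is no measured size or direction to lean on, and compound 2 offers no guidance either, sitting at the same limit.

For compound 3 the estimate is that the step from compound 1 is an at least 1.2-fold lower number from compound 1 to compound 3 (0.07 log units; that floor lies within the scatter), with no direction beyond the scatter expected. Compound 3 is estimated at 250000 nM in this assay, within 30000 nM to 1000000 nM, and most likely again reported only as a limit.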

Compound 3, half-maximal inhibitory concentration: > 300000 nM
Compound 3: a limit, no number; the forecaster's own chance of this, stated with the estimate: 70%; middle value at least 1.2-fold (0.07 log units) away from the limit.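

No step between compound 1 and compound 3 can be read in this assay, since both readings are limits of the assay and not numbers: the limit of > 300000 nM in this assay, at which 3 of the 3 values shown sit.

The compounds shown leave open whether thiophen-3-yl in place of bromo changes inhibition at all, and whether any compound on this core gives a measurable value.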